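Swapping Isopropyl for Amino on the Outer Ring

A few compounds are considered here, and "the series" means these few. Any claim that something is new, unique, unknown or untested is made for them only; others in the source may bear on it.

Measured compounds:
Compound 1, `Cc1cc(C(=O)Nc2nn[nH]n2)nc(-c2ccccc2)c1`, gives 50% in a functional assay on the whole organism with Rattus norvegicus as the target, at a dose of 3 mg/kg by the oral route; on this read-out lower numbers stand for a weaker effect and higher numbers for a stronger effect at the one dose given.
Compound 2, `Cc1cc(C(=O)Nc2nn[nH]n2)nc(-c2ccc(C(C)C)cc2)c1`, gives 100% in this assay.

Within the data shown here, compound 2 stands at the top of these two numbers; the only other measured compound is compound 1, and the one recorded step runs a number 50 percentage points higher from compound 1 to compound 2 (beyond the scatter). So adding isopropyl on an aromatic carbon of the outer ring raised the read-out in this assay by a large amount, well beyond the scatter.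

Compound 3, `Cc1cc(C(=O)Nc2nn[nH]n2)nc(-c2ccc(N)cc2)c1`, has not yet been measured. It differs from compound 2 in one place: amino in place of isopropyl on an aromatic carbon. Among the measured compounds shown here, no measured step shows what amino does at this position. For the measured compounds named here, the single step that bears on the site is the one from compound 1 to compound 2, which tells only that the bare ring is weaker than the isopropyl-bearing ring. Amino is a smaller group than isopropyl, so the read-out in this assay is expected to fall back somewhat toward that of compound 1, though the direction is uncertain.

For compound 3 the expected step is a number 35 percentage points lower from compound 2 to compound 3 (beyond the scatter), and the estimate is 65% with a range from 30% to 95%.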

Compound 3, a percentage reported as inhibition, in the whole organism at one dose (the size of the read-out at that dose, not a potency): 100%
Compound 3: middle estimate off by 35 percentage points, on the low side, outside the stated range (above it).
By their numbers in this assay, from the lowest: compound 1; then compounds 2 and 3 (each within the scatter of the next).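

In this assay, the step of no change at the digits printed from compound 2 to compound 3 (within the scatter) shows that this aromatic carbon does not need isopropyl to give this result: amino, with 1 heavy atom, 1 hydrogen-bond donor and 1 hydrogen-bond acceptor, serves as well as isopropyl, with 3 heavy atoms and neither donor nor acceptor. The step of a number 50 percentage points higher from compound 1 to compound 3 (beyond the scatter) matches the earlier gain from isopropyl, so among the three compounds shown, both groups at this place stand clearly above the hydrogen of compound 1, even though the two groups share little in size or in hydrogen-bond counts. Nothing available explains why two such different groups give matching read-outs here.

The compounds shown leave open whether a different group on this carbon, such as a carboxylic acid, a methoxy group or a longer chain, would keep the read-out or lose it. They also leave open whether compound 2 and compound 3 match in potency, since a result at one dose gives the size of the effect and a difference might appear only at lower doses.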